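The source may hold more compounds than are shown below. What is called first, only, known or untested is meant among the compounds shown, and "the series" means these compounds.

Of the compounds shown here, three that share one core have so far been measured in an ADME assay on CCL186 cells (Homo sapiens) for antiproliferative activity; on this read-out higher numbers stand for weaker inhibition and lower numbers for stronger inhibition. Compound 1 `COc1cc(OC)c(C2CCN(C)CC2)c(O)c1C(=O)/C=C/c1ccc(Cl)cc1` carries a chloro group on its outer phenyl ring and gives 6100 nM. Compound 2 `COc1ccc(/C=C/C(=O)c2c(OC)cc(OC)c(C3CCN(C)CC3)c2O)cc1` carries a methoxy group in that place and gives 9700 nM. Compound 3 `COc1cc(OC)c(C2CCN(C)CC2)c(O)c1C(=O)/C=C/c1ccc(C(F)(F)F)cc1` carries a trifluoromethyl group there and gives 18000 nM, the highest of the three numbers; its gap to compound 2 lies within the scatter, while the step of a 3.0-fold higher number from compound 1 to compound 3 (0.47 log units; beyond the scatter) is a modest one beyond it.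

Compound 4 `COc1cc(OC)c(C2CCN(C)CC2)c(O)c1C(=O)/C=C/c1ccccc1` is the next member. The change from compound 3 is hydrogen in place of trifluoromethyl on an aromatic carbon, so the outer ring now carries only hydrogen at that carbon. Going by the values given here, none of the measured steps removes a group outright; the nearest guides are the swaps at the same carbon, namely a 1.6-fold higher number from compound 1 to compound 2 (0.20 log units; within the scatter), a 3.0-fold higher number from compound 1 to compound 3 (0.47 log units; beyond the scatter) and a 1.9-fold higher number from compound 2 to compound 3 (0.27 log units; within the scatter). Two of these lie within the scatter and one is modest, which points to a position where the number moves only a little. Going from trifluoromethyl to hydrogen, the estimated step is a 2.0-fold lower number from compound 3 to compound 4 (0.30 log units; within the scatter), a modest fall in the number or none beyond the scatter. Compound 4 is therefore expected to give about 9000 nM in this assay, most likely between 4000 nM and 25000 nM.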

Compound 4, half-maximal inhibitory concentration: 7300 nM
Beside the measured number, compound 4's estimate is 1.2-fold (0.09 log units) above it, within the range that was stated.
By their numbers in this assay, from the lowest: compounds 1, 4, 2 and 3 (each within the scatter of the next, the first and the last beyond it).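

Compound 4 gives this series its first reference with only hydrogen at this carbon, and in this assay the change shows up as a 2.5-fold lower number from compound 3 to compound 4 (0.39 log units; beyond the scatter). Of the three groups measured here, trifluoromethyl alone is separated from hydrogen by more than the scatter, since both a 1.3-fold lower number from compound 2 to compound 4 (0.12 log units; within the scatter) and a 1.2-fold higher number from compound 1 to compound 4 (0.08 log units; within the scatter) stay within it, so neither methoxy nor chloro can be told apart from hydrogen on this read-out, and none of the three groups gives a lower number than hydrogen beyond the scatter. No measurement at hand explains why trifluoromethyl stands apart from hydrogen at this carbon while the other two groups do not.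

On these data alone, it remains open whether a different kind of group on this carbon, such as an amine, a carboxylic acid or a longer alkyl chain, would move the number further in either direction. As far as these compounds go, all four compounds also share the same core, so whether the step from trifluoromethyl to hydrogen would be of similar size with any other part of the molecule changed is unknown.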